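The source may report more compounds than this note shows. Statements on the series, on what has been measured and on what is new or still open speak of the compounds shown alone.

Compound 1 `O=C(c1ccc(OCCCN2CC[C@H](NS(=O)(=O)c3cccc(Cl)c3)C2)cc1)C1CC1` gives 700 nM in an assay on isolated protein for binding affinity to histamine H2 receptor (Homo sapiens); a lower number here means a stronger inhibitor, a higher number a weaker inhibitor.
Compound 2 `O=C(c1ccc(OCCCN2CC[C@H](NS(=O)(=O)c3ccccc3F)C2)cc1)C1CC1` gives 1550 nM in this assay.
Compound 3 `Cc1ccc(S(=O)(=O)N[C@H]2CCN(CCCOc3ccc(C(=O)C4CC4)cc3)C2)cc1` gives 380 nM in this assay.

Among the three measured compounds, compound 3 has the lowest number; its separation from compound 1 is a 1.8-fold lower number from compound 1 to compound 3 (0.27 log units; within the scatter), and from compound 2 it is a 4.1-fold lower number from compound 2 to compound 3 (0.61 log units; beyond the scatter), the latter being the only one of its gaps that stands beyond the scatter. Compound 4 `O=C(c1ccc(OCCCN2CC[C@H](NS(=O)(=O)c3ccccc3)C2)cc1)C1CC1` has not yet been measured in this assay. The difference from compound 3 is hydrogen in place of methyl on an aromatic carbon. No measured step removes a methyl; the steps shown, a 2.2-fold higher number from compound 1 to compound 2 (0.35 log units; beyond the scatter) and a 1.8-fold lower number from compound 1 to compound 3 (0.27 log units; within the scatter), exchange one substituted phenyl on the sulfonyl sulfur for another and stay modest. Compound 4 is therefore expected to show a modest step of a 1.7-fold higher number from compound 3 to compound 4 (0.23 log units; within the scatter) from compound 3. Compound 4 is estimated at 650 nM, within 250 nM to 1700 nM.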

Compound 4, inhibition constant: 1200 nM
Compound 4: the middle estimate sits 1.8-fold (0.27 log units) below what was measured; the measured number falls inside the stated range.
By their numbers in this assay, from the lowest: compounds 3, 1, 4 and 2 (each within the scatter of the next, the first and the last beyond it).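

Taking the methyl off the 4-methylphenyl group to leave phenyl gives a 3.2-fold higher number from compound 3 to compound 4 (0.50 log units; beyond the scatter), the first direct view of what this one methyl contributes in this assay. Hydrogen at the ring is not separated from the chloro or fluoro compounds, with a 1.3-fold lower number from compound 2 to compound 4 (0.11 log units; within the scatter) and a 1.7-fold higher number from compound 1 to compound 4 (0.23 log units; within the scatter), so of these three groups only methyl stands apart from hydrogen beyond the scatter. Nothing available here explains this step. As far as these compounds go, it remains open whether an ethyl, a methoxy or an amine, para to the large group, would match methyl, and whether the step would hold on another core.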